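The source may hold more compounds than are shown below. What is called first, only, known or untested is meant among the compounds shown, and "the series" means these compounds.

Of the compounds shown here, two sharing one core have been measured in an ADME assay on NHDF cells (Homo sapiens) for cytotoxicity, read by MTT assay, with a stated time of 72 h; a lower number here means a stronger inhibitor, a higher number a weaker inhibitor. Compound 1 (`COc1cccc(/C=C2\CCC/C(=C\c3cccc(Cl)c3)C2=O)c1OC`) gives 21400 nM, and compound 2 (`COc1cccc(/C=C2\CCC/C(=C\c3ccc(Cl)c(Cl)c3)C2=O)c1OC`) gives 25500 nM, so compound 2 stands level with compound 1 within the scatter of repeated measurements. Compound 3 (`COc1cccc(/C=C2\CCC/C(=C\c3ccc(O)c(Cl)c3)C2=O)c1OC`) keeps the core of compound 2 and changes one group, with hydroxy in place of chloro on an aromatic carbon, turning 3,4-dichlorophenyl into 3-chloro-4-hydroxyphenyl (hydroxy in place of chloro on an aromatic carbon). Among the compounds with values here, the only measured step at this ring carbon is chloro in place of hydrogen, a 1.2-fold higher number from compound 1 to compound 2 (0.08 log units; within the scatter), and it lies within the scatter, so no step beyond the scatter is expected in this assay, although no hydroxy compound has yet been measured. The expected step is a 1.3-fold lower number from compound 2 to compound 3 (0.11 log units; within the scatter). Compound 3 is estimated at 20000 nM, with an expected range of 9000 nM to 45000 nM.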

Compound 3, half-maximal inhibitory concentration: 39500 nM
Estimate against measurement, compound 3: 2.0-fold (0.30 log units) below; the measured number falls inside the stated range.
By their numbers in this assay, from the lowest: compounds 1, 2 and 3 (each within the scatter of the next).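

At the ring carbon para to a large group, this assay now has three occupants to compare: hydrogen, chloro and hydroxy. Hydroxy in place of chloro gives a 1.5-fold higher number from compound 2 to compound 3 (0.19 log units; within the scatter) and hydroxy in place of hydrogen gives a 1.8-fold higher number from compound 1 to compound 3 (0.27 log units; within the scatter) so neither change moves the number beyond the usual scatter. This extends the earlier chloro result to a group counted as a hydrogen-bond donor and acceptor, where chloro counts as neither. No measurement at hand explains these readings.

As far as these compounds go, whether an amine or a carboxylic acid at this carbon would also stay within the scatter remains open. From the compounds shown here alone, all three compounds also keep the chloro group ortho to this carbon, so how hydroxy reads without that chloro is unknown.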